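The compounds below may be only part of what the source reports. "The series", "measured", "known", "first", "only" and "open" are said of these compounds alone.

In a functional assay on CHO cells for agonist activity at Melanocortin receptor 4 (Homo sapiens), read by cAMP accumulation (a higher number here means a larger maximal response, a lower number a smaller maximal response), three close relatives of one core have been measured. Compound 1 `CC[C@H](NC(C)=O)c1cc(Cl)ccc1C1CCN(C(=O)[C@H]2CN(C(C)(C)C)C[C@@H]2c2ccc(F)cc2F)CC1` gives 83%. Compound 2 `CC[C@H](NC(C)=O)c1cc(Cl)ccc1C1CCN(C(=O)[C@@H]2CN(C(C)(C)C)C[C@H]2c2ccc(F)cc2F)CC1` gives 108%, and the step of a number 25 percentage points higher from compound 1 to compound 2 (beyond the scatter) arises because the fact that compounds 1 and 2 differ only in the configuration as drawn is the only thing that separates these two. Compound 3 `CC[C@H](NC(C)=O)c1cc(Cl)ccc1C1CCN(C(=O)[C@@H]2CN(C(C)(C)C)C[C@H]2c2ccc(Cl)cc2Cl)CC1` gives 48%; the step of a number 60 percentage points lower from compound 2 to compound 3 (beyond the scatter) is the largest in this small set. Compound 3 therefore stands lowest of the three numbers, clearly beneath compound 1 and far beneath compound 2.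

Compound 4 `CC[C@H](NC(C)=O)c1cc(Cl)ccc1C1CCN(C(=O)[C@@H]2CN(C(C)(C)C)C[C@H]2c2ccc(F)cc2Cl)CC1` is the next compound to be measured. It differs from compound 3 at a single point: fluoro in place of chloro on an aromatic carbon. Seen one bond further out, this is 2,4-dichlorophenyl turning into 2-chloro-4-fluorophenyl, which places compound 4 halfway between compound 3 and compound 2 on that ring. Among the compounds with values here, the step that bears on this is the one from compound 2 to compound 3, where the full exchange of both fluoro groups for chloro groups cost a large share of the response. Returning one fluoro is expected to recover part of that loss, so an upward step beyond the scatter is expected, though smaller than the full drop. The expected step is a number 27 percentage points higher from compound 3 to compound 4 (beyond the scatter). Compound 4 is expected to give 75%, with a range from 50% to 100%.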

Compound 4, largest response reached (reported as percent of maximum), in percent of the reference or control that the assay uses: 84%
Compound 4: middle estimate off by 9 percentage points, on the low side; the range from low to high includes it.
By their numbers in this assay, from the lowest: compound 3; then compounds 1 and 4 (each within the scatter of the next); then compound 2.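

Until now the two halogens on this phenyl ring had only been seen changing together, and compound 4 separates that single large drop into two parts. In this assay, changing only the chloro that sits para to the large group to fluoro gives a number 36 percentage points higher from compound 3 to compound 4 (beyond the scatter), so this one atom carries real weight even with the other chloro still in place. Seen from the other side, 2,4-difluorophenyl turning into 2-chloro-4-fluorophenyl gives a number 24 percentage points lower from compound 2 to compound 4 (beyond the scatter), and since both steps lie beyond the scatter, neither halogen exchange alone accounts for the whole loss of response.

Going by these compounds, the missing partner on this ring is 4-chloro-2-fluorophenyl, and it remains open what that ring would give, along with a methoxy group or a nitrile in the place para to the large group, which would show whether the response follows halogens only or other small groups as well. The values show how large each step is, but nothing known about these compounds explains why exchanging chloro and fluoro at this ring moves the response.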